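A few compounds are considered here, and "the series" means these few. Any claim that something is new, unique, unknown or untested is made for them only; others in the source may bear on it.

In an ADME assay on Caco-2 cells (Homo sapiens) for permeability, read by LC-MS, with a stated time of 2 h, at pH 7.4, tested at 10 uM (on this read-out lower numbers stand for lower permeability and higher numbers for higher permeability), compound 3 `C[C@H]1Cn2c(nnc2C(F)(F)F)CN1C(=O)c1cccc(C(F)(F)c2n[nH]c(=O)c3ccccc23)c1` gives 6.7 10^-6 cm/s. Compound 1 `C[C@H]1Cn2c(nnc2C(F)(F)F)CN1C(=O)c1cccc(C(F)(F)c2n[nH]c(=O)c3c2CCCC3)c1` gives 3.6 10^-6 cm/s and compound 2 `C[C@H]1Cn2c(Br)nnc2CN1C(=O)c1cccc(C(F)(F)c2n[nH]c(=O)c3ccccc23)c1` gives 12.1 10^-6 cm/s, which places compound 3 within the scatter of both: a 1.9-fold higher number from compound 1 to compound 3 (0.27 log units; within the scatter), and a 1.8-fold lower number from compound 2 to compound 3 (0.26 log units; within the scatter). Compound 4 `O=C(c1cccc(C(F)(F)c2n[nH]c(=O)c3ccccc23)c1)N1CCn2c(nnc2C(F)(F)F)C1` has hydrogen in place of methyl on a saturated ring carbon. Neither measured step involves that carbon, so both serve only as a gauge of size, and both stayed within the scatter. No step beyond the scatter is expected in this assay, and no direction can be called from these data. The estimated step is a 1.1-fold lower number from compound 3 to compound 4 (0.03 log units; within the scatter). For compound 4 the estimated value is 6.2 10^-6 cm/s, with an expected range of 3.2 10^-6 cm/s to 12 10^-6 cm/s.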

Compound 4, apparent permeability: 5.7 10^-6 cm/s
The estimate for compound 4 lay 1.1-fold (0.04 log units) above the measured number, and the stated range covers the measured number.
By their numbers in this assay, from the lowest: compounds 1, 4, 3 and 2 (each within the scatter of the next, the first and the last beyond it).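

In this assay, among these compounds, hydrogen in place of methyl on this saturated ring carbon gives a 1.2-fold lower number from compound 3 to compound 4 (0.07 log units; within the scatter) and is the first measured step at this position. Within the compounds shown, the methyl is therefore not required to keep the permeability number in the range of compound 3. Nothing measured on these compounds gives a reason for the size of this step.

From the compounds shown here alone, whether an ethyl, methoxymethyl or aminomethyl group on this carbon would stay within the scatter of compound 3 remains open. Also open, going by these compounds, is whether the same step would hold with bromo in place of trifluoromethyl.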